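Acid to methyl ester at the aryl terminus

A few compounds are considered here, and "the series" means these few. Any claim that something is new, unique, unknown or untested is made for them only; others in the source may bear on it.

In an assay on HEK293 cells for positive allosteric modulation of metabotropic glutamate receptor 3 (Rattus norvegicus), read by thallium flux, with a stated time of 2.5 min (on this read-out higher numbers stand for larger maximal responses and lower numbers for smaller maximal responses), compound 3 `Cc1c(OCCCCOc2ccc(C(=O)O)cc2)ccc(C(=O)CC(C)C)c1O` gives 51.9%; compound 1 `Cc1cc(C(=O)O)ccc1OCCCCOc1ccc(C(=O)CC(C)C)c(O)c1C` with 42.1% lies within the scatter of it, while compound 2 `COC(=O)c1ccc(OCCCCOc2ccc(C(=O)CC3CCCC3)c(O)c2C)cc1` at 22% sits beyond the scatter and lower. Among the compounds with values here, the single measured step, a number 9.8 percentage points higher from compound 1 to compound 3 (within the scatter), concerns a different part of the molecule and does not touch the change at hand. Compound 4 `COC(=O)c1ccc(OCCCCOc2ccc(C(=O)CC(C)C)c(O)c2C)cc1` differs from compound 3 by methyl in place of hydrogen on an oxygen next to a carbonyl group. Within the data shown here, no measured step bears on this change directly; compound 2 also carries the methoxycarbonyl group yet differs from compound 3 in two places, so its lower value only hints at a loss. Compound 4 is therefore expected to come in lower, a number 19.9 percentage points lower from compound 3 to compound 4 (beyond the scatter), at an estimated 32% with a range of 18% to 48%.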

Compound 4, largest response reached (reported as percent of maximum), in percent of the reference or control that the assay uses: 22.7%
For compound 4 the middle estimate is 9.3 percentage points above the measured one, and the stated range covers the measured number.
By their numbers in this assay, from the lowest: compounds 2 and 4 (each within the scatter of the next); then compounds 1 and 3 (each within the scatter of the next).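

Carboxy to methoxycarbonyl at this terminus now has a direct reading: the maximal response falls (a number 29.2 percentage points lower from compound 3 to compound 4 (beyond the scatter)), so the loss no longer rests on compound 2, which differs in two places. With methoxycarbonyl held, isopropyl in place of cyclopentyl leaves the response unresolved (a number 0.7 percentage points higher from compound 2 to compound 4 (within the scatter)). Replacing 4-carboxy-2-methylphenyl with 4-(methoxycarbonyl)phenyl also lowers it (a number 19.4 percentage points lower from compound 1 to compound 4 (beyond the scatter)).

No supporting data explain the fall. From the compounds shown here alone, whether a primary amide or a tetrazole at this terminus would retain the response seen with the carboxylic acid remains open.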